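This account rests on a few compounds, and the source may have more. Where it says the series, first, only, none or still open, it means among the compounds named here.

Measured so far in a functional assay on the whole organism (strain Wistar) for inhibition, with Rattus norvegicus as the target, read by paw edema, with stated times of 30 min and 3 h, at a dose of 0.05 mmol/kg by the oral route; a higher number here means more inhibition at the dose given (going by the name of the read-out), a lower number less inhibition:
compound 1 `Cc1ccc(C2=NN(c3ccc(S(C)(=O)=O)cc3)C(=O)CC2)cc1` gives 46.7%
compound 2 `CCc1ccc(C2=NN(c3ccc(S(C)(=O)=O)cc3)C(=O)CC2)cc1` gives 46.7%
compound 3 `CS(=O)(=O)c1ccc(N2N=C(c3ccc(Br)cc3)CCC2=O)cc1` gives 10%

Compound 3 holds the lowest of the three numbers in this assay. The nearest measured compound to it is compound 1, with the step of a number 36.7 percentage points lower from compound 1 to compound 3 (beyond the scatter); compound 2 lies just as far off, with the step of a number 36.7 percentage points lower from compound 2 to compound 3 (beyond the scatter). Compound 1 and compound 2 differ from each other only by a methyl in place of hydrogen on a saturated chain carbon bound to an aromatic carbon, and that step, no change at the digits printed from compound 1 to compound 2 (within the scatter), left the read-out where it was.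

Compound 4 `CC(C)(C)c1ccc(C2=NN(c3ccc(S(C)(=O)=O)cc3)C(=O)CC2)cc1` is the next compound to go into this assay. It differs from compound 3 as follows: tert-butyl in place of bromo on an aromatic carbon. Among the measured compounds shown here, the steps that bear on this change are the two that put bromo in place of methyl or ethyl, a number 36.7 percentage points lower from compound 1 to compound 3 (beyond the scatter) and a number 36.7 percentage points lower from compound 2 to compound 3 (beyond the scatter), both large and downward. Compound 4 reverses that move: bromo leaves and tert-butyl, an alkyl like methyl and ethyl, enters at the same aromatic carbon. For the measured compounds named here, the two alkyls measured so far did not separate from each other, as no change at the digits printed from compound 1 to compound 2 (within the scatter) shows, so a third alkyl is expected to land near them; no measured compound carries tert-butyl, however, so the range is kept wide. Compound 4 is therefore expected to give 44%, within 22% to 60%, an expected upward step of a number 34 percentage points higher from compound 3 to compound 4 (beyond the scatter).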

Compound 4, a percentage reported as inhibition, in the whole organism at one dose (the size of the read-out at that dose, not a potency): 50%
Beside the measured number, compound 4's estimate is 6 percentage points below it; the measured number falls inside the stated range.
By their numbers in this assay, from the lowest: compound 3; then compounds 1, 2 and 4 (each within the scatter of the next).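

In this assay, tert-butyl at this aromatic carbon brings the read-out back from the low level seen with bromo (a number 40 percentage points higher from compound 3 to compound 4 (beyond the scatter)), so among these compounds the low number goes with bromo and not with the series as a whole. Among the compounds shown here, the position also accepts a much larger alkyl group than the earlier compounds showed: tert-butyl, with its 4 carbon atoms, does not separate from ethyl (a number 3.3 percentage points higher from compound 2 to compound 4 (within the scatter)) or from methyl (a number 3.3 percentage points higher from compound 1 to compound 4 (within the scatter)), and compounds 1, 2 and 4 therefore form a single group with no order among them, with compound 3 alone standing apart. Nothing among the available data accounts for the gap between bromo and these three alkyl groups.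

The compounds shown leave open whether the low read-out belongs to bromo alone or would also appear with chloro or fluoro, and whether methoxy, hydroxy or an amine at this carbon would sit with the alkyl groups or with bromo. With one dose only, they also leave open whether compounds 1, 2 and 4 would stay together at other doses.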